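Compound 1 to compound 4: swapping the nitrogen substituent

The compounds below may be only part of what the source reports. "The series", "measured", "known", "first", "only" and "open" are said of these compounds alone.

Measured in a functional assay on Jurkat cells (Homo sapiens) for antiproliferative activity, read by MTT assay, with a stated time of 72 h (a lower number here means a stronger inhibitor, a higher number a weaker inhibitor), so far:
- compound 1 `COc1cc(-c2ncnn2-c2cccc(N)c2)cc(OC)c1OC` gives > 10000 nM as a limit
- compound 2 `COc1ccc(-c2ncnn2-c2cc(OC)c(OC)c(OC)c2)cc1` gives 50 nM as a number
- compound 3 `COc1cc(-n2ncnc2-c2ccc(Cl)c(Cl)c2)cc(OC)c1OC` gives > 10000 nM as a limit

Compound 1 has only a limit and no number, namely (the limit of > 10000 nM in this assay, at which 2 of the 3 values shown sit). Compound 4 `COc1ccc(-n2ncnc2-c2cc(OC)c(OC)c(OC)c2)cc1` has 4-methoxyphenyl in place of 3-aminophenyl on an aromatic nitrogen, (4-methoxyphenyl in place of 3-aminophenyl on an aromatic nitrogen). For the measured compounds named here, one measured step bears on this, though it lies on an aromatic carbon: an at least 200-fold higher number from compound 2 to compound 3 (2.30 log units; beyond the scatter), large, with 3,4-dichlorophenyl in place of 4-methoxyphenyl. A large move toward a lower number in this assay is therefore expected, the estimated step being an at least 66-fold lower number from compound 1 to compound 4 (1.82 log units; beyond the scatter) as a loose guide. Compound 4 is estimated at 150 nM, with 20 nM to 3000 nM as the expected range.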

Compound 4, half-maximal inhibitory concentration: 93 nM
Compound 4: the middle estimate sits 1.6-fold (0.21 log units) above what was measured, within the range that was stated.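

In this assay, for the compounds shown here, the aromatic nitrogen of the shared core proves sensitive to its substituent: 4-methoxyphenyl in place of 3-aminophenyl gives an at least 100-fold lower number from compound 1 to compound 4 (2.03 log units; beyond the scatter), the only step read at this position. The size of this step is a bound, not an exact figure, since compound 1 has only a limit: the limit of > 10000 nM in this assay, at which 2 of the 4 values shown sit.

The step swaps the amine for the methoxy group in one move and does not separate the two. As far as these compounds go, how an unsubstituted phenyl, a hydroxyl or a longer ether such as ethoxy on this ring would read in this assay stays open.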